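This account rests on a few compounds, and the source may have more. Where it says the series, first, only, none or still open, it means among the compounds named here.

Measured so far:
Compound 1, `CC(C)[C@H](CC(=O)O)NC(=O)[C@@H]1CCCN1S(=O)(=O)c1cc(Cl)cc(Cl)c1`: 362 nM
Compound 2, `O=C(O)CCNC(=O)[C@@H]1CCCN1S(=O)(=O)c1cc(Cl)cc(Cl)c1`: 1510 nM

In an assay on RPMI-8866 cells for inhibition of integrin alpha-4/beta-1 (Homo sapiens) (a higher number here means a weaker inhibitor, a lower number a stronger inhibitor), compound 2 stands at the highest of the two numbers. Its nearest neighbour is compound 1, which carries an isopropyl group where compound 2 carries hydrogen. Among the compounds with values here, the one measured step, a 4.2-fold higher number from compound 1 to compound 2 (0.62 log units; beyond the scatter), shows that removing that group weakened the inhibitor beyond the scatter. Compound 3, `CCOc1ccc([C@@H](CC(=O)O)NC(=O)[C@@H]2CCCN2S(=O)(=O)c2cc(Cl)cc(Cl)c2)cc1`, differs from compound 2 by 4-ethoxyphenyl in place of hydrogen on a saturated chain carbon bound to an amide-type nitrogen and a saturated chain carbon. Within the data shown here, the only step bearing on this position is a 4.2-fold higher number from compound 1 to compound 2 (0.62 log units; beyond the scatter), which is read here in reverse: a substituent returns to the carbon that compound 2 leaves bare, so a lower number in this assay is expected, likely of similar or larger size than that step, though a 4-ethoxyphenyl group has no measured precedent in this set. Compound 3 is therefore estimated at 120 nM, with a range from 25 nM to 600 nM. This corresponds to an expected step of a 13-fold lower number from compound 2 to compound 3 (1.10 log units; beyond the scatter).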

Compound 3, half-maximal inhibitory concentration: 0.27 nM
The estimate for compound 3 lay 440-fold (2.65 log units) above the measured number, outside the stated range (below it).
By their numbers in this assay, from the lowest: compound 3; then compound 1; then compound 2.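

Placing 4-ethoxyphenyl on the saturated chain carbon bound to an amide-type nitrogen and a saturated chain carbon gives a 5600-fold lower number from compound 2 to compound 3 (3.75 log units; beyond the scatter) in this assay and shows that this position accepts an aromatic ring. The same carbon responds far more strongly than the earlier pair showed, where hydrogen in place of isopropyl gave a 4.2-fold higher number from compound 1 to compound 2 (0.62 log units; beyond the scatter) and left the size of the possible gain unseen; compound 1 with isopropyl gives 362 nM and compound 3 with 4-ethoxyphenyl gives 0.27 nM on this carbon. No measurement at hand explains the size of this gain.

The compounds shown leave open how much of the gain belongs to the ring and how much to the ethoxy group, which an unsubstituted phenyl or a 4-methoxyphenyl group would separate. They also leave open whether other aromatic groups on this carbon, such as pyridyl, would serve as well.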